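Shortening the Alkyl Chain on a Pyrrolidine Dithiocarbamate Phosphate

This account rests on a few compounds, and the source may have more. Where it says the series, first, only, none or still open, it means among the compounds named here.

Measured compounds:
- compound 1 `CCCCCCCCCCOP(=O)(O)OCCSC(=S)N1CCCC1`: > 100000 nM
- compound 2 `CCCCCCCCOP(=O)(O)OCCSC(=S)N1CCCCCC1`: > 100000 nM
- compound 3 `CCCCCCCCCCOP(=O)(O)OCCSC(=S)N1CCN(C)CC1`: > 100000 nM

In an ADME assay on HEK293 cells (Homo sapiens) for inhibition, read by MTT assay, with stated times of 18 h and 4 h (on this read-out higher numbers stand for weaker inhibition and lower numbers for stronger inhibition), compound 1 gives > 100000 nM, which is a limit of the assay and not a number. In this assay compound 2 gives > 100000 nM, again a limit. Compound 3 gives > 100000 nM, once more a limit. Going by the values given here, all three values therefore sit at the limit of > 100000 nM in this assay, at which 3 of the 3 values shown sit, and the one change among them that can be followed, a step that the two limits leave unreadable from compound 1 to compound 3, cannot be read in size.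

Compound 4 `CCCCCCOP(=O)(O)OCCSC(=S)N1CCCC1` is the one that has not yet been measured. It differs from compound 1 in one place: hydrogen in place of butyl on a saturated chain carbon, six bonds along the chain from an oxygen on an unsaturated carbon. The chain is thus shortened, while the rest of the shared core stays as in compound 1.

Among the compounds with values here, no measured step bears on this change, since the only step on record concerns the ring on the thiocarbonyl carbon and is itself unreadable. What the three measured compounds do show is that none of them reaches a measurable number in this assay. On that basis compound 4 is expected to behave alike, with the step that the limit leaves unreadable from compound 1 to compound 4 expected to stay within the scatter. The estimate for compound 4 is 150000 nM, with a range from 60000 nM to 500000 nM.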

Compound 4, half-maximal inhibitory concentration: > 100000 nM
Compound 4 was reported as a limit; the forecaster's own chance of this, stated with the estimate: 85%; the middle value is on the limit's open side.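

In this assay, compound 1 and compound 4 both stand at a limit of the assay and not at a number, so the step between them, from the longer chain to the shorter one, cannot be read in size. The compounds shown leave open whether changing the chain or the ring on the thiocarbonyl carbon has any effect on this read-out, as every value rests on the same limit: the limit of > 100000 nM in this assay, at which 4 of the 4 values shown sit.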